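The source may hold more compounds than are shown below. What is called first, only, known or untested is meant among the compounds shown, and "the series" means these compounds.

Two compounds have been measured in an assay on HEK293 cells for agonist activity at Toll-like receptor 2 (Homo sapiens); on this read-out lower numbers stand for an effect already at smaller amounts and higher numbers for an effect only at larger amounts of compound:
compound 1, `CCCCCCCCCCCC(=O)OC[C@H](CSC[C@@H](N)C(=O)N[C@H](C)CO)OC(=O)CCCCCCCCCCC`, gives 22200 nM;
compound 2, `CCCCCCCCCCCC(=O)OC[C@H](CSC[C@@H](N)C(=O)NCCCC(C)(C)CO)OC(=O)CCCCCCCCCCC`, gives 30700 nM.

Compound 1 has the lowest of the two numbers, and the nearest neighbour lies at a 1.4-fold higher number from compound 1 to compound 2 (0.14 log units; within the scatter). Compound 3, `CCCCCCCCCCCC(=O)OC[C@H](CSC[C@@H](N)C(=O)NC(C)c1ccc(O)cc1)OC(=O)CCCCCCCCCCC`, has not yet been measured in this assay. It differs from compound 1 in one place: 1-(4-hydroxyphenyl)ethyl in place of 1-(hydroxymethyl)ethyl on an amide-type nitrogen. For the measured compounds named here, the only measured step that bears on this position put 4-(hydroxymethyl)-4-methylpentyl in place of 1-(hydroxymethyl)ethyl on the same amide-type nitrogen and gave a 1.4-fold higher number from compound 1 to compound 2 (0.14 log units; within the scatter), no movement beyond the scatter. The group entering in compound 3 carries a six-membered aromatic ring of carbon only, which neither measured compound has, so that single step offers only a loose guide and leaves the direction open. Going by the values given here, for compound 3 the expected step is a 1.1-fold lower number from compound 1 to compound 3 (0.05 log units; within the scatter), since nothing measured so far points beyond the scatter. Compound 3 is estimated at 20000 nM in this assay, with a range of 7000 nM to 60000 nM reflecting the untested ring.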

Compound 3, half-maximal effective concentration: 2890 nM
The estimate for compound 3 lay 6.9-fold (0.84 log units) above the measured number; the measured number lies below the stated range.
By their numbers in this assay, from the lowest: compound 3; then compounds 1 and 2 (each within the scatter of the next).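

In this assay, the amide-type nitrogen proved responsive to the group it carries, with a 7.7-fold lower number from compound 1 to compound 3 (0.89 log units; beyond the scatter) when 1-(4-hydroxyphenyl)ethyl replaced 1-(hydroxymethyl)ethyl. The same group also gave an 11-fold lower number from compound 2 to compound 3 (1.03 log units; beyond the scatter) against 4-(hydroxymethyl)-4-methylpentyl, so among these three compounds only the group with a six-membered aromatic ring of carbon only stands apart, while the two open-chain groups with a hydroxyl remain within the scatter of each other. The position therefore tolerates a larger group of 9 heavy atoms and gives a lower number with it, but no measurement here accounts for that difference.

The compounds shown do not separate the contribution of the aromatic ring from that of its hydroxyl, a question that 1-phenylethyl, 1-(4-methoxyphenyl)ethyl or 1-(4-aminophenyl)ethyl on the same nitrogen would address. They also leave open how the two mirror-image forms of the 1-(4-hydroxyphenyl)ethyl group compare, since compound 3 has no defined stereocentre in that group, and whether a shorter link such as a 4-hydroxyphenyl group directly on the nitrogen would keep the lower number.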